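The compounds below may be only part of what the source reports. "The series", "measured", "known", "first", "only" and "open" are said of these compounds alone.

Measured compounds: compound 1 `COc1ccc(-c2nn3cc(-c4cccc(N)c4)nc3s2)cc1OC`, compound 2 `C=C(Br)C(=O)Nc1cccc(-c2cn3nc(-c4ccc(OC)c(OC)c4)sc3n2)c1`, compound 3 `Nc1cccc(-c2cn3nc(-c4ccc(F)cc4)sc3n2)c1`.

In a functional assay on HeLa cells (Homo sapiens) for inhibition, read by cell counting, with a stated time of 4 days (on this read-out lower numbers stand for stronger inhibition and higher numbers for weaker inhibition), compound 1 gives 26000 nM. Compound 2 gives 610 nM in this assay. For compound 3 this assay reports only a limit, >= 250000 nM. Compound 2 thus stands lowest of the two numbers shown, the nearest being compound 1, reached through the step of a 43-fold lower number from compound 1 to compound 2 (1.63 log units; beyond the scatter).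

Compound 4 `C=C(Br)C(=O)Nc1cccc(-c2cn3nc(-c4ccc(Cl)cc4)sc3n2)c1` has not yet been measured. It differs from compound 2 in one place: 4-chlorophenyl in place of 3,4-dimethoxyphenyl on an aromatic carbon. No measured step follows this change; the only step shown, from compound 1 to compound 2, concerns the (1-bromoethenyl)carbonyl and is large, so compound 4 keeps the group that set compound 2 apart. Compound 3, which also lacks the 3,4-dimethoxyphenyl, sits only at the limit of >= 250000 nM in this assay, at which 1 of the 3 values shown sits. On that basis a weakening is expected, a 4.9-fold higher number from compound 2 to compound 4 (0.69 log units; beyond the scatter), beyond the scatter. Compound 4 is therefore estimated at 3000 nM in this assay, within 600 nM to 20000 nM.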

Compound 4, half-maximal inhibitory concentration: 3000 nM
Estimate against measurement, compound 4: no gap at the digits printed; the measured number falls inside the stated range.
By their numbers in this assay, from the lowest: compound 2; then compound 4; then compound 1. At a limit, above all of these: compound 3.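

For the compounds shown here, with the (1-bromoethenyl)carbonyl kept in place, the change on this aromatic carbon of the five-membered ring gives the first readable step at this position in this assay: a 4.9-fold higher number from compound 2 to compound 4 (0.69 log units; beyond the scatter). The 3,4-dimethoxyphenyl can thus be exchanged for 4-chlorophenyl at a modest cost, smaller than the step at the nitrogen, a 43-fold lower number from compound 1 to compound 2 (1.63 log units; beyond the scatter). The same aryl change cannot be read on the compounds with the free aromatic amine, since compound 3 gives only a limit: the limit of >= 250000 nM in this assay, at which 1 of the 4 values shown sits.

The compounds shown leave open whether the loss follows from the two methoxy groups leaving or from the chlorine entering, which a plain phenyl or a 4-methoxyphenyl would help to separate. They also leave open how a ring bearing a carboxylic acid or a morpholine would behave at this carbon.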